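Removing the Aryl Carbonyl from a Non-Cytotoxic Amide

The source may hold more compounds than are shown below. What is called first, only, known or untested is meant among the compounds shown, and "the series" means these compounds.

In an ADME assay on Raji cells (Homo sapiens) for cytotoxicity, read by CellTiter-Glo and resazurin assay, with a stated time of 72 h (a higher number here means that more compound is needed for the effect, a lower number that less compound is needed), compound 1 `CCOC(=O)CCCCCOc1cccc(CN(C(=O)c2ccc(-c3cccc(Cl)c3)cc2)C(C)C)c1` gives only a limit, > 18400 nM. Compound 2 `CCCN(Cc1ccc(OCCCCCC(=O)OCC)cc1)C(=O)c1ccc(Br)cc1` likewise gives only a limit in this assay, > 26000 nM. Compound 2 therefore stands at the limit of > 26000 nM in this assay, at which 1 of the 2 values shown sits. Compound 1 stands at the limit of > 18400 nM in this assay, at which 1 of the 2 values shown sits. Going by the values given here, neither compound has a measured number in this assay, so no ordering between the two can be drawn, and no step between measured compounds is available to guide an expectation.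

Compound 3 `CCCNCc1ccc(OCCCCCC(=O)OCC)cc1` differs from compound 2 in one place: hydrogen in place of (4-bromophenyl)carbonyl on an amine nitrogen. The (4-bromophenyl)carbonyl is thus removed and the amine nitrogen keeps only its two saturated chain carbons. With both measured values sitting at limits, nothing in the data points to any cytotoxic effect that the change could strengthen or weaken, and the expected step in this assay is none beyond the scatter, written as a step that the limit leaves unreadable from compound 2 to compound 3. Compound 3 is accordingly expected to give about 30000 nM in this assay, somewhere between 10000 nM and 100000 nM, most probably reported once more only as a limit.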

Compound 3, half-maximal effective concentration: > 26000 nM
Compound 3: a limit, no number (the forecaster's own chance of this, stated with the estimate: 85%); the middle value lies beyond the limit too.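

Compound 2 and compound 3 are both reported only as limits in this assay, and no step can be read for the removal of the (4-bromophenyl)carbonyl from the amine nitrogen. The compounds shown leave open whether any of them has a measurable effect in this assay, and at what concentration such an effect would appear.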